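Swapping the Aryl Group on a Weak Cytotoxic Scaffold

This account rests on a few compounds, and the source may have more. Where it says the series, first, only, none or still open, it means among the compounds named here.

Compound 1 `Cc1cc(NCCO)nc(SCc2nc3ccccc3[nH]2)n1`: in a functional assay on MGC-803 cells (Homo sapiens) for cytotoxicity, read by MTT assay, with a stated time of 72 h (a lower number here means a stronger inhibitor, a higher number a weaker inhibitor), compound 1 gives > 100000 nM, which is a limit of the assay and not a number.
Compound 2 `COc1ccccc1Nc1cc(C)nc(SCc2nc3ccccc3[nH]2)n1`: in this assay compound 2 gives 56200 nM.

Within the data shown here, compound 2 holds the only number measured; the other value is a limit. Among the measured compounds shown here, the only measured step, an at least 1.7-fold lower number from compound 1 to compound 2 (0.25 log units; that floor lies within the scatter), replaced a 2-hydroxyethyl group by 2-methoxyphenyl on the same nitrogen. Compound 3 `Cc1ccc(Nc2cc(C)nc(SCc3nc4ccccc4[nH]3)n2)cc1` differs from compound 2 by 4-methylphenyl in place of 2-methoxyphenyl on a nitrogen on an aromatic ring. Both groups are aryl rings on that nitrogen, so the measured step gives little guidance, and no change beyond the scatter is expected: a 1.2-fold lower number from compound 2 to compound 3 (0.10 log units; within the scatter). Compound 3 is estimated at 45000 nM in this assay, expected between 15000 nM and 120000 nM.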

Compound 3, half-maximal inhibitory concentration: 7390 nM
The estimate for compound 3 lay 6.1-fold (0.78 log units) above the measured number, outside the stated range (below it).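

Two aryl groups on the same nitrogen are not interchangeable in this series: 4-methylphenyl in place of 2-methoxyphenyl gives a 7.6-fold lower number from compound 2 to compound 3 (0.88 log units; beyond the scatter). So the identity of the aryl group matters at this position, not merely its presence. Replacing 2-hydroxyethyl now gives a change that clears the scatter, an at least 13-fold lower number from compound 1 to compound 3 (1.13 log units; beyond the scatter). Compound 1 stands at a limit of the assay and not a number: the limit of > 100000 nM in this assay, at which 1 of the 3 values shown sits.

Still open, going by these compounds, is which part of the swap counts: the methoxy group leaving, the methyl group entering, or where each sits on the phenyl ring. Also open, on these data alone, is how plain phenyl or 4-methoxyphenyl would read on this nitrogen.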